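A few compounds are considered here, and "the series" means these few. Any claim that something is new, unique, unknown or untested is made for them only; others in the source may bear on it.

Compound 1 `CN1CCN(CCCS(=O)(=O)c2ccc3nc(NC(=O)NC(=O)c4cc(C5CC5)ccc4Cl)sc3c2)CC1` gives 2.9 in a physicochemical assay for lipophilicity; on this read-out higher numbers stand for higher lipophilicity and lower numbers for lower lipophilicity. Compound 2 `CN1CCN(CCCS(=O)(=O)c2ccc3nc(NC(=O)NC(=O)c4cc(-n5cccc5)ccc4Cl)sc3c2)CC1` gives 2.6, the lowest of the three numbers; compound 3 `CN1CCC(S(=O)(=O)c2ccc3nc(NC(=O)NC(=O)c4cc5c(cc4Cl)CCN5C)sc3c2)CC1` gives 2.8, its nearest neighbour, while compound 1 is furthest, both gaps lying within the scatter. Within the data shown here, the only measured step that touches the same position is a number 0.30 log units lower from compound 1 to compound 2 (within the scatter), a change within the scatter. Compound 4 `Cc1ccn(-c2ccc(Cl)c(C(=O)NC(=O)Nc3nc4ccc(S(=O)(=O)CCCN5CCN(C)CC5)cc4s3)c2)n1` differs from compound 2 as follows: 3-methyl-1H-pyrazol-1-yl in place of 1H-pyrrol-1-yl on an aromatic carbon. Among the measured compounds shown here, no measured step shows this exact exchange, so the account can only lean on the small size of the one step at this position, and no step beyond the scatter is expected in this assay. Compound 4 is therefore estimated at 2.5, between 2.1 and 2.9, which means an expected step of a number 0.10 log units lower from compound 2 to compound 4 (within the scatter).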

Compound 4, distribution coefficient: 2.6
The estimate for compound 4 lay 0.10 log units below the measured number; low and high end bracket the measured number.
By their numbers in this assay, from the lowest: compounds 2, 4, 3 and 1 (each within the scatter of the next).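

In this assay the 3-methyl-1H-pyrazol-1-yl group in place of 1H-pyrrol-1-yl gives no change at the digits printed from compound 2 to compound 4 (within the scatter) even though a methyl group and a second ring hetero atom enter. Set against cyclopropyl, the same group gives a number 0.30 log units lower from compound 1 to compound 4 (within the scatter) so all three groups at this position now lie within the scatter of one another. Nothing shown gives a reason for this. From the compounds shown here alone, whether an amine or a carboxylic acid at this position, para to the chloro group, would give a step beyond the scatter remains open.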